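The compounds below may be only part of what the source reports. "The series", "measured", "known", "first", "only" and "open" are said of these compounds alone.

Compound 1, `O=C(O)CC1COc2cc(OCc3nnc(-c4ccccc4)o3)ccc21`, gives 1.54% in a functional assay on CHO cells for agonist activity at Free fatty acid receptor 1 (Homo sapiens), read by FLIPR and calcium flux, tested at 100 nM; on this read-out lower numbers stand for a weaker effect and higher numbers for a stronger effect at the one concentration tested.
Compound 2, `Cc1nc(-c2ccccc2)sc1COc1ccc2c(c1)OCC2CC(=O)O`, gives 54.8% in this assay.
Compound 3, `Cc1cc(COc2ccc3c(c2)OCC3CC(=O)O)nn1-c1ccccc1`, gives 0.98% in this assay.

Among these three, compound 2 stands highest in this assay, and both gaps to it lie beyond the scatter: the nearest neighbour is compound 1, and the furthest is compound 3, each well below it. Compound 4, `Cc1ccc(-c2nc(C)c(COc3ccc4c(c3)OCC4CC(=O)O)s2)cc1`, has not yet been measured. It differs from compound 2 in one place: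

methyl in place of hydrogen on an aromatic carbon

Among the measured compounds shown here, no step between two measured compounds shows what such a change does here, so the expectation rests on compound 2 alone. A methyl in place of hydrogen on an aromatic carbon is a small addition, and the step is expected to stay within, or only slightly beyond, the scatter, with no clear direction favoured. Compound 4 is therefore expected to land near its parent, at 58%, somewhere between 28% and 85%. This estimate means a step of a number 3.2 percentage points higher from compound 2 to compound 4 (within the scatter), expected to be modest.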

Compound 4, a percentage reported as activity, at one concentration (the size of the read-out at that concentration, not a potency): 54.9%
Compound 4: middle estimate off by 3.1 percentage points, on the high side; the measured number falls inside the stated range.
By their numbers in this assay, from the lowest: compounds 3 and 1 (each within the scatter of the next); then compounds 2 and 4 (each within the scatter of the next).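

In this assay the change from phenyl to 4-methylphenyl is read as a single step (a number 0.1 percentage points higher from compound 2 to compound 4 (within the scatter)). Among the compounds shown here, this is the first reading of any change at this place, on an aromatic carbon of a six-membered aromatic ring of carbon only, para to a large group, and it shows that a methyl there leaves the read-out at the one concentration tested within the scatter. No measurement shown offers an explanation for this outcome.

Open, going by these compounds, is whether a larger or different group at the same place, such as methoxy, chlorine or trifluoromethyl, would also leave the read-out within the scatter. On these data alone, a read-out at one concentration also gives no potency, so any difference in potency between compound 2 and compound 4 remains unknown.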